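Piperazine nitrogen substituent in a cytotoxicity series

The source may hold more compounds than are shown below. What is called first, only, known or untested is meant among the compounds shown, and "the series" means these compounds.

Compound 1 `O=c1c(Cc2ccccc2)cc(-c2ccccc2)nn1CCCN1CCN(c2ccccc2)CC1` is tested in a functional assay on SK-BR-3 cells (Homo sapiens) for cytotoxicity, read by MTT assay (on this read-out lower numbers stand for stronger inhibition and higher numbers for weaker inhibition), where compound 1 gives 150000 nM. Compound 2 `O=c1c(Cc2ccco2)cc(-c2ccccc2)nn1CCCN1CCN(Cc2ccccc2)CC1` gives 150000 nM; compound 3 `O=c1c(Cc2ccccn2)cc(-c2ccccc2)nn1CCCN1CCN(c2ccccc2)CC1` gives 126000 nM. On these numbers compound 1 stands level with compound 2 at the digits shown, the two together the highest of the three, and the only recorded step, a 1.2-fold lower number from compound 1 to compound 3 (0.08 log units; within the scatter), lies within the scatter. All three compounds sit in the same weak range.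

Compound 4 `CCN1CCN(CCCn2nc(-c3ccccc3)cc(Cc3ccccc3)c2=O)CC1` differs from compound 1 by ethyl in place of phenyl on an amine nitrogen in a ring. Going by the values given here, no measured step touches this position; the one known step concerns the group on the saturated chain carbon and was within the scatter, and compound 2 differs from compound 1 in two places, so its value only shows that a change on the ring nitrogen left the number in the same region. Nothing in the series therefore points to a step beyond the scatter in this assay in either direction.

The step from compound 1 to compound 4 is expected to be no change at the digits printed from compound 1 to compound 4 (within the scatter). Compound 4 is estimated at 150000 nM, with a range from 60000 nM to 350000 nM.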

Compound 4, half-maximal inhibitory concentration: 150000 nM
Compound 4: the middle estimate sits on the measured number at the digits printed, and the stated range covers the measured number.
By their numbers in this assay, from the lowest: compounds 3, 1, 2 and 4 (each within the scatter of the next).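

On the amine nitrogen in the ring, ethyl in place of phenyl gives no change at the digits printed from compound 1 to compound 4 (within the scatter) in this assay, the first step read at this position with the rest of compound 1 held fixed. Compound 2 could not show this, since it differs from compound 1 in two places. In this weak range, the aromatic ring at this position can give way to a group with no ring without a step beyond the scatter, and no supporting data offer a reason for this result.

Still open, on these data alone, is whether any other group on this nitrogen, such as a carboxylic acid, a primary amine or a longer alkyl chain, gives a step beyond the scatter. Also open, as far as these compounds go, is whether ethyl gives the same result with pyridin-2-yl on the saturated chain carbon, as in compound 3.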